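Swapping Cyclohexyl for Methyl on the Core Nitrogen

A few compounds are considered here, and "the series" means these few. Any claim that something is new, unique, unknown or untested is made for them only; others in the source may bear on it.

Of the compounds shown here, three have been tested in an ADME assay on MT4 cells (Homo sapiens) for cytotoxicity, read by MTT assay, with a stated time of 96 h; on this read-out lower numbers stand for higher toxicity in this test and higher numbers for lower toxicity in this test. Compound 1 `CCC(=O)Nc1ccc(-c2nc3cc(C(F)(F)F)ccc3n2C2CCCCC2)cc1` gives 17000 nM. Compound 3 `Nc1ccc(-c2nc3cc(Cl)c(Cl)cc3[nH]2)cc1` gives 17000 nM, the same number at the digits shown, so the two stand level, and they are the two lowest of the three. Compound 2 `COc1ccc(-c2nc3cc(C(F)(F)F)ccc3[nH]2)c(OC)c1OC`, which carries no group on the ring nitrogen of the shared core and a different set of substituents on its attached benzene ring, gives 93000 nM, a higher number that lies beyond the usual scatter of this test. No two of these compounds differ in one place only, so no single change can be read from them directly.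

Compound 4 `CCC(=O)Nc1ccc(-c2nc3cc(C(F)(F)F)ccc3n2C)cc1` is built from compound 1 by one change: methyl in place of cyclohexyl on an aromatic nitrogen. Because compound 2 gives 93000 nM with no group on that nitrogen, a somewhat higher number seems plausible for compound 4, although compound 2 differs in other places as well. The expected step is a 1.8-fold higher number from compound 1 to compound 4 (0.25 log units; within the scatter), a small rise that stays within the usual scatter. For compound 4 the estimate is 30000 nM, with a range from 12000 nM to 80000 nM.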

Compound 4, half-maximal cytotoxic concentration: 8000 nM
Estimate against measurement, compound 4: 3.8-fold (0.57 log units) above, outside the stated range (below it).
By their numbers in this assay, from the lowest: compound 4; then compounds 1 and 3 (each within the scatter of the next); then compound 2.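

In this assay, the swap on the aromatic nitrogen gives a 2.1-fold lower number from compound 1 to compound 4 (0.33 log units; beyond the scatter), a modest step but one beyond the scatter. Among these compounds, no earlier pair differed in one place only, so this is the first direct sign that the group on this nitrogen can shift the read-out, and here methyl in place of cyclohexyl goes with higher toxicity in this test. Nothing in the data shown gives a reason for this step.

A single pair cannot show how the read-out follows the group on this nitrogen: an ethyl, an isopropyl, a cyclopentyl or a plain hydrogen there, with the rest of compound 1 kept, could land between these two numbers or outside them. As far as these compounds go, whether the same swap moves the read-out the same way with other groups elsewhere on the shared core also stays open.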